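Cytotoxicity series on V79 cells: acyl chain extension

The source may report more compounds than this note shows. Statements on the series, on what has been measured and on what is new or still open speak of the compounds shown alone.

Measured compounds:
compound 1 `CC(C)CCc1c(O)ccc2ccc(=O)oc12`, in a functional assay on V79 cells (Cricetulus griseus) for cytotoxicity (on this read-out lower numbers stand for stronger inhibition and higher numbers for weaker inhibition), compound 1 gives 40000 nM
compound 2 `CCCOc1ccc2ccc(=O)oc2c1CCC(C)C`, in this assay compound 2 gives 5600 nM
compound 3 `CC(=O)c1ccc2ccc(=O)oc2c1CCC(C)C`, in this assay compound 3 gives 60000 nM

Compound 3 has the highest number of the three measured. Its nearest neighbour is compound 1, with a 1.5-fold higher number from compound 1 to compound 3 (0.18 log units; within the scatter), a gap within the scatter; its furthest is compound 2, with an 11-fold higher number from compound 2 to compound 3 (1.03 log units; beyond the scatter), a large gap beyond the scatter.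

Compound 4 `CCCC(=O)c1ccc2ccc(=O)oc2c1CCC(C)C` differs from compound 3 by ethyl in place of hydrogen on a saturated chain carbon bound to a carbonyl carbon, that is, the acetyl of compound 3 becomes propylcarbonyl. Among the compounds with values here, no measured step extends an acyl chain. Within the data shown here, the only measured step that lengthens a chain at all is a 7.1-fold lower number from compound 1 to compound 2 (0.85 log units; beyond the scatter), where propyl enters on an oxygen rather than on a saturated chain carbon bound to a carbonyl carbon, so it bears on the present step only loosely. On that thin basis a modest lowering of the number is expected for compound 4, with the direction held with low confidence and the size possibly not beyond the scatter; the step expected from compound 3 is a 2.0-fold lower number from compound 3 to compound 4 (0.30 log units; within the scatter). The estimate for compound 4 in this assay is 30000 nM, with a range from 8000 nM to 100000 nM.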

Compound 4, half-maximal inhibitory concentration: 58000 nM
For compound 4 the middle estimate is 1.9-fold (0.29 log units) below the measured one, and the stated range covers the measured number.
By their numbers in this assay, from the lowest: compound 2; then compounds 1, 4 and 3 (each within the scatter of the next).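

In this assay, within the data shown here, the first measured step at a saturated chain carbon bound to a carbonyl carbon, from acetyl to propylcarbonyl, stays inside the scatter: a 1.0-fold lower number from compound 3 to compound 4 (0.01 log units; within the scatter). The result also separates propylcarbonyl from propoxy as clearly as acetyl was separated, with propylcarbonyl in place of propoxy giving a 10-fold higher number from compound 2 to compound 4 (1.02 log units; beyond the scatter), while propylcarbonyl in place of hydroxy gives a 1.5-fold higher number from compound 1 to compound 4 (0.16 log units; within the scatter), so among the four compounds only compound 2, the propoxy member, stands apart from the others. No measured evidence bearing on the reason for these steps is available.

Going by these compounds, two acyl chains give a single step, so it remains open whether a longer chain such as pentylcarbonyl, or a branched acyl chain, would also stay within the scatter of acetyl. Also open, on these data alone, is whether a longer ether chain such as butoxy, or an amide or a carboxylic acid on the same aromatic carbon, would give a number close to that of compound 2 or to those of the other three compounds.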